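The source may hold more compounds than are shown below. What is called first, only, known or untested is meant among the compounds shown, and "the series" means these compounds.

Three compounds have been measured in an assay on isolated protein for inhibition of Dihydrofolate reductase (Homo sapiens), read by spectrophotometry; a higher number here means a weaker inhibitor, a lower number a stronger inhibitor:
Compound 1, `CCN(Cc1nc2cc(C(F)(F)F)ccc2nc1-c1ccccc1)c1ccc(C)cc1`, gives 4000 nM.
Compound 2, `CCN(Cc1nc2cc(C(F)(F)F)ccc2nc1-c1ccccc1)c1ccc(F)cc1`, gives 3000 nM.
Compound 3, `CCN(Cc1nc2cc(C(F)(F)F)ccc2nc1-c1ccccc1)c1ccc(OC)c(OC)c1`, gives 4000 nM.

All three share one core and differ only in the aryl group on the amine nitrogen. Compound 3 stands level with compound 1, the two together at the highest numbers of the three; its nearest neighbour is compound 1, with no change at the digits printed from compound 1 to compound 3 (within the scatter), and its furthest is compound 2, with a 1.3-fold higher number from compound 2 to compound 3 (0.12 log units; within the scatter). The remaining step is likewise small, a 1.3-fold lower number from compound 1 to compound 2 (0.12 log units; within the scatter). None of these three steps goes beyond the scatter, so within this set the choice of aryl group on the amine nitrogen has made no measurable difference in this assay.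

Compound 4, `CCN(Cc1nc2cc(C(F)(F)F)ccc2nc1-c1ccccc1)c1cc(OC)c(OC)c(OC)c1`, has not yet been measured. It differs from compound 3 in one place: methoxy in place of hydrogen on an aromatic carbon. Going by the values given here, the steps that bear on this change are those that alter the same aryl group, and all three were within the scatter. On that basis the added methoxy is expected to leave this assay essentially unchanged, neither clearly higher nor clearly lower. The estimate for compound 4 is therefore 4000 nM, with a range from 2000 nM to 8000 nM. The expected step is no change at the digits printed from compound 3 to compound 4 (within the scatter), which is to say none beyond the scatter.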

Compound 4, inhibition constant: 6000 nM
For compound 4 the middle estimate is 1.5-fold (0.18 log units) below the measured one; measured number inside the range.
By their numbers in this assay, from the lowest: compounds 2, 1, 3 and 4 (each within the scatter of the next).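

Adding a methoxy group to the 3,4-dimethoxyphenyl on the amine nitrogen, at the place ortho to a methoxy group and meta to a large group, gives a 1.5-fold higher number from compound 3 to compound 4 (0.18 log units; within the scatter) in this assay and so turns 3,4-dimethoxyphenyl into 3,4,5-trimethoxyphenyl without a step beyond the scatter. Going by these compounds alone, the same holds against the two aryl groups with a single substituent, with a 1.5-fold higher number from compound 1 to compound 4 (0.18 log units; within the scatter) and a 2.0-fold higher number from compound 2 to compound 4 (0.30 log units; within the scatter) in this assay, so the insensitivity seen among the earlier compounds now extends to an aryl group carrying three methoxy groups, and none of the four compounds goes against it. No measurement shown here offers any explanation for these numbers.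

Going by these compounds, whether any change at this position can move the number beyond the scatter stays open, since all four aryl groups carry only methyl, fluoro or methoxy substituents, and an amine or a carboxylic acid on this ring could behave differently. The shared core also leaves open what a longer chain in place of the ethyl on the amine nitrogen would do in this assay.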